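The source may hold more compounds than are shown below. What is called first, only, known or untested is meant among the compounds shown, and "the series" means these compounds.

Measured so far in a functional assay on HEK293 cells for positive allosteric modulation of metabotropic glutamate receptor 5 (Homo sapiens), read by calcium flux; on this read-out lower numbers stand for smaller maximal responses and higher numbers for larger maximal responses:
- compound 1 `CC(C)C(=O)N1CCCn2nc(COc3ccccc3)cc21`: 59%
- compound 2 `CC(C)(C)C(=O)N1CCCn2nc(COc3ccccc3)cc21`: 64%
- compound 3 `O=C(c1ccccc1)N1CCCn2nc(COc3ccccc3)cc21`: 63%

Compound 1 has the lowest of the three values, yet its distance to compound 3 is a number 4 percentage points higher from compound 1 to compound 3 (within the scatter) and its distance to compound 2 is a number 5 percentage points higher from compound 1 to compound 2 (within the scatter), so the three compounds cannot be told apart on this read-out. The new compound, compound 4 `O=C(c1ccno1)N1CCCn2nc(COc3ccccc3)cc21`, has not yet been measured. It differs from compound 1 in one place: 1,2-oxazol-5-yl in place of isopropyl on a carbonyl carbon. The closest guide is the step in which a phenyl took the place of the isopropyl on the same carbonyl carbon, which gave a number 4 percentage points higher from compound 1 to compound 3 (within the scatter); replacing tert-butyl by phenyl gave a number 1 percentage points lower from compound 2 to compound 3 (within the scatter). Both show that swapping the group on the carbonyl carbon, whether chain or ring, changed nothing beyond the scatter. For compound 4 a step of a number 3 percentage points higher from compound 1 to compound 4 (within the scatter) is therefore expected, meaning no change beyond the scatter. Compound 4 is estimated to give 62%, within the range 46% to 78%.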

Compound 4, largest response reached (reported as percent of maximum), in percent of the reference or control that the assay uses: 22%
Beside the measured number, compound 4's estimate is 40 percentage points above it, and the stated range ends above it.
By their numbers in this assay, from the lowest: compound 4; then compounds 1, 3 and 2 (each within the scatter of the next).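

In this assay, the group on the carbonyl carbon now proves able to matter: isopropyl, tert-butyl and phenyl could not be told apart, but 1,2-oxazol-5-yl in that place gives a number 37 percentage points lower from compound 1 to compound 4 (beyond the scatter), along with a number 41 percentage points lower from compound 3 to compound 4 (beyond the scatter) and a number 42 percentage points lower from compound 2 to compound 4 (beyond the scatter). Compound 3 also carries an aromatic ring on this carbonyl carbon, so having a ring there does not by itself go with the drop, although only these two rings can be compared. Nothing measured here gives a reason for the drop.

On these data alone, it remains open whether the drop follows the five-membered ring or its nitrogen and oxygen, which 1,2-oxazol-3-yl, thiophen-2-yl or pyridin-2-yl on the same carbonyl carbon could help separate. Also open, as far as these compounds go, is whether a chain containing oxygen, such as methoxymethyl, would lower the response too.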